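Fluoro for Methoxy: What to Expect for Compound 3

The compounds below may be only part of what the source reports. "The series", "measured", "known", "first", "only" and "open" are said of these compounds alone.

Compound 1, `Cc1cc(C)c2sc(NC(=O)c3ccc(C(F)(F)F)cc3)nc2c1`: 1.4 ug/mL
Compound 2, `COc1ccccc1NC(=O)Nc1nc2ccc(F)cc2s1`: > 10 ug/mL

Of the compounds shown here, two have been measured in a functional assay on NUGC-3 cells (Homo sapiens) for antiproliferative activity, read by sulforhodamine B assay; on this read-out lower numbers stand for stronger inhibition of growth and higher numbers for weaker inhibition of growth. Compound 1 gives 1.4 ug/mL in this assay. For compound 2 the result is > 10 ug/mL, which is a limit of the assay and not a number; this is the limit of > 10 ug/mL in this assay, at which 1 of the 2 values shown sits. Compound 2 therefore stands at the weak end of what this assay can report.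

Compound 3, `O=C(Nc1nc2ccc(F)cc2s1)Nc1ccccc1F`, differs from compound 2 in one place: fluoro in place of methoxy on an aromatic carbon

No measured pair among these compounds shows what this change does, so the expectation rests on compound 2 alone. Because compound 2 sits at > 10 ug/mL, the step to compound 3 is expected to be small, a step that the limit leaves unreadable from compound 2 to compound 3, and not beyond the scatter in either direction. Compound 3 is expected to give about 12 ug/mL in this assay, most likely between 3 ug/mL and 40 ug/mL, with a fair chance that only a limit is reported again.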

Compound 3, concentration for 50% growth inhibition: > 10 ug/mL
Compound 3 gave a limit, no number (the forecaster's own chance of this, stated with the estimate: 60%); the middle value is on the limit's open side.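

Going by these compounds alone, compound 2 and compound 3 both end at a limit in this assay and not at a number, so no step between them can be read: the limit of > 10 ug/mL in this assay, at which 2 of the 3 values shown sit.

The compounds shown leave open whether fluoro in place of methoxy changes growth inhibition at all, and in which direction.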